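This account rests on a few compounds, and the source may have more. Where it says the series, first, only, none or still open, it means among the compounds named here.

Measured in a functional assay (aorta) with Rattus norvegicus as the target, in the presence of a further agent that is not named here; a lower number here means that less compound is needed, a higher number that more compound is needed for the effect:
- compound 1 `COC(=O)C1=C(C)N=C(C)/C(=C(/O)OC)C1c1ccccc1OCCO[N+](=O)[O-]`: 56 nM
- compound 2 `COC(=O)C1=C(C)N=C(C)/C(=C(/O)OC)C1c1cccc(OCc2nonc2C)c1`: 640 nM
- compound 3 `COC(=O)C1=C(C)N=C(C)/C(=C(/O)OC)C1c1cccc(OCc2nonc2C(N)=O)c1`: 3500 nM

Compound 1 holds the lowest number of the three, and compound 2 and compound 3 both lie beyond the scatter from it, with compound 2 the nearer.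

The next entry is compound 4 `COC(=O)C1=C(C)N=C(C)/C(=C(/O)OC)C1c1ccccc1OCc1nonc1C(N)=O`. Its change from compound 1 is 4-carbamoyl-1,2,5-oxadiazol-3-yl in place of (nitrooxy)methyl on a saturated chain carbon bound to an oxygen on an aromatic ring.

Among the compounds with values here, only one measured step bears on this change: a 5.5-fold higher number from compound 2 to compound 3 (0.74 log units; beyond the scatter). It shows what the carbamoyl group does in place of methyl on an aromatic carbon, with the number rising. Compound 3 already carries the entering group, attached at another place on the molecule, and compound 3 reads 3500 nM. Within the data shown here, no measured pair shows the (nitrooxy)methyl group being replaced directly, and no measured pair shows the effect of moving the entering group, so the transfer is uncertain and the range stays wide.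

Neither compound with the ring group comes close to compound 1, so a large rise is expected, estimated as a 36-fold higher number from compound 1 to compound 4 (1.55 log units; beyond the scatter). For compound 4 the estimated value is 2000 nM, with an expected range from 500 nM to 8000 nM.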

Compound 4, half-maximal effective concentration: 970 nM
Estimate against measurement, compound 4: 2.1-fold (0.31 log units) above; the range from low to high includes it.
By their numbers in this assay, from the lowest: compound 1; then compounds 2 and 4 (each within the scatter of the next); then compound 3.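

In this assay, within the data shown here, the direct exchange at this place gives a 17-fold higher number from compound 1 to compound 4 (1.24 log units; beyond the scatter), the first measured change on a saturated chain carbon bound to an oxygen on an aromatic ring, whereas the earlier step touched only an aromatic carbon. This step removes (nitrooxy)methyl and introduces the whole 4-carbamoyl-1,2,5-oxadiazol-3-yl group in one move, so the contribution of the leaving group cannot be separated from that of the entering one; it runs in the same direction as a 5.5-fold higher number from compound 2 to compound 3 (0.74 log units; beyond the scatter), but the two steps concern different changes and two pairs establish no general rule. No measurement at hand accounts for the rise.

Still open, on these data alone, is whether a simpler group at this place, such as a plain methyl, a hydroxyl or a 3-(nitrooxy)propyl chain, would stay close to compound 1 or follow compound 4. Equally open, as far as these compounds go, is what a carboxylic acid or an amine would do in place of the carbamoyl group on the ring of compound 4.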